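The compounds below may be only part of what the source reports. "The series", "measured", "known", "first", "only" and "open" are said of these compounds alone.

Measured so far in a functional assay on T-24 cells (Homo sapiens) for antiproliferative activity, read by MTT assay, with a stated time of 48 h; on this read-out lower numbers stand for stronger inhibition and higher numbers for weaker inhibition:

Compound 1 `O=C(Nc1ccccc1)Nc1cccc(CNc2nccnc2Cl)c1` gives 19800 nM
Compound 2 `O=C(Nc1cccc(CNc2nccnc2Cl)c1)Nc1ccc(Cl)cc1Cl` gives 5740 nM
Compound 3 `O=C(Nc1cccc(CNc2nccnc2Cl)c1)Nc1ccc(Cl)cc1Br` awaits measurement

Compound 2 holds the lower of the two numbers, at 5740 nM, and stands alone at that end of this small set. Compound 3 departs from it by one change, (bromo in place of chloro on an aromatic carbon), with bromo in place of chloro on an aromatic carbon, ortho to a large group and meta to a chloro group. The 2,4-dichlorophenyl group thus becomes 2-bromo-4-chlorophenyl, and the rest of the structure stays the same.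

Among the compounds with values here, only one measured step bears on this, and only indirectly: a 3.4-fold lower number from compound 1 to compound 2 (0.54 log units; beyond the scatter), which put 2,4-dichlorophenyl in place of phenyl. Within the data shown here, that modest step compares a substituted ring with a bare one, and no measured pair shows bromo exchanged for chloro. No step beyond the scatter is therefore expected in this assay, and no firm direction. The expected change is a 1.1-fold lower number from compound 2 to compound 3 (0.06 log units; within the scatter). Compound 3 is estimated at 5000 nM, with an expected range from 2400 nM to 10500 nM.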

Compound 3, half-maximal inhibitory concentration: 6650 nM
Estimate against measurement, compound 3: 1.3-fold (0.12 log units) below; the range from low to high includes it.
By their numbers in this assay, from the lowest: compounds 2 and 3 (each within the scatter of the next); then compound 1.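

In this assay, bromo in place of chloro, ortho to a large group and meta to a chloro group, gives a 1.2-fold higher number from compound 2 to compound 3 (0.06 log units; within the scatter) and so the two halogens cannot be told apart at this position on this read-out. The advantage over the unsubstituted phenyl group persists through the exchange: 2-bromo-4-chlorophenyl in place of phenyl gives a 3.0-fold lower number from compound 1 to compound 3 (0.47 log units; beyond the scatter) and this modest step stands alongside the one printed for 2,4-dichlorophenyl, a 3.4-fold lower number from compound 1 to compound 2 (0.54 log units; beyond the scatter) and thus a second halogen pair on this ring also gives a number beyond the scatter from that of compound 1. No measurement accompanying these compounds accounts for this result.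

Both halogens entered the ring together in each of these steps, so the compounds shown leave open how much of the step away from compound 1 belongs to this position and how much to the chloro group that stays. On these data alone, whether a methoxy group, a methyl group or an amine at this position would give a number close to those of compound 2 and compound 3 also remains open.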